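The source may hold more compounds than are shown below. What is called first, only, known or untested is meant among the compounds shown, and "the series" means these compounds.

Three compounds were measured in a functional assay on K562 cells (Homo sapiens) for inhibition, read by fluorescence and resazurin assay, with a stated time of 72 h; on this read-out higher numbers stand for weaker inhibition of growth and lower numbers for stronger inhibition of growth:

compound 1 `NCCCCNc1nc(Nc2ccc(Oc3nccs3)cc2)c2ncn(C3CCCC3)c2n1`: 5980 nM
compound 2 `OCCCCNc1nc(Nc2ccc(Oc3nccs3)cc2)c2ncn(C3CCCC3)c2n1`: 6080 nM
compound 3 `NCCCCNc1nc(Nc2ccc(N3CCN(Cc4ccccc4)CC3)cc2)c2ncn(C3CCC(O)C3)c2n1`: 1630 nM

Compound 1 and compound 2 differ by one change, (hydroxy in place of amino on a saturated chain carbon, four bonds along the chain from a nitrogen on an aromatic ring), and in this assay this change gives a 1.0-fold higher number from compound 1 to compound 2 (0.01 log units; within the scatter). Compound 3 carries a different core; how the core of compound 3 differs from that of compound 1 is not broken down here. Its number is the lowest of the three, and its gap to each of the other two lies beyond the scatter.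

Compound 4 `OCCCCNc1nc(Nc2ccc(N3CCN(Cc4ccccc4)CC3)cc2)c2ncn(C3CCC(O)C3)c2n1` is the not yet measured partner of compound 3, differing from it by hydroxy in place of amino on a saturated chain carbon, four bonds along the chain from a nitrogen on an aromatic ring, the same change at the same place as between compound 1 and compound 2. Because that earlier step read a 1.0-fold higher number from compound 1 to compound 2 (0.01 log units; within the scatter), the step from compound 3 to compound 4 is expected to be small, about a 1.0-fold higher number from compound 3 to compound 4 (0.02 log units; within the scatter). Compound 4 is therefore estimated at 1700 nM in this assay, expected to fall between 800 nM and 3600 nM.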

Compound 4, concentration for 50% growth inhibition: 3730 nM
For compound 4 the middle estimate is 2.2-fold (0.34 log units) below the measured one; measured number outside the range, above it.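

Hydroxy in place of amino on a saturated chain carbon, four bonds along the chain from a nitrogen on an aromatic ring, gives a 2.3-fold higher number from compound 3 to compound 4 (0.36 log units; beyond the scatter) in this assay, while on the other core the same change gives a 1.0-fold higher number from compound 1 to compound 2 (0.01 log units; within the scatter). Although only the newer step lies beyond the scatter, the two steps cannot be told apart: the same change on two cores in this assay, a 1.0-fold higher number (0.01 log units; within the scatter) from compound 1 to compound 2 and a 2.3-fold higher number (0.36 log units; beyond the scatter) from compound 3 to compound 4, 2.3-fold (0.35 log units) apart, within the scatter of two such steps. This shows no dependence of the change on the core, but with one pair per core it does not show that the change carries over unaltered either.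

The compounds shown leave open how a carboxylic acid, a methoxy group or a longer chain would read at this place. They also leave open how the change would read on a third core.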